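Removing a methyl: compound 4 projected from compound 3

The source may hold more compounds than are shown below. What is called first, only, known or untested is meant among the compounds shown, and "the series" means these compounds.

Compound 1 `N/C(=N\NC(=S)N1CCOCC1)c1ccccn1`, compound 2 `Cc1ccnc(/C(N)=N/NC(=S)N2CCOCC2)c1` and compound 3 `Cc1ccnc(/C(N)=N/NC(=S)N2CCN(c3ccccn3)CC2)c1` have been run in a functional assay on A-431 cells (Homo sapiens) for cytotoxicity, read by MTT assay, with a stated time of 72 h; on this read-out higher numbers stand for weaker inhibition and lower numbers for stronger inhibition. Compound 1 gives 4800 nM, compound 2 gives 6800 nM and compound 3 gives 15500 nM, the highest of the three. Compound 2 and compound 1 differ by hydrogen in place of methyl on an aromatic carbon, a step of a 1.4-fold lower number from compound 2 to compound 1 (0.15 log units; within the scatter). The difference between the core of compound 3 and the core of compound 2 is not broken down here. Compound 4 `N/C(=N\NC(=S)N1CCN(c2ccccn2)CC1)c1ccccn1` has not yet been measured; it differs from compound 3 by hydrogen in place of methyl on an aromatic carbon, the same change as before, at the same place. In this assay compound 4 is expected to move by a 1.4-fold lower number from compound 3 to compound 4 (0.15 log units; within the scatter), resting on the step of a 1.4-fold lower number from compound 2 to compound 1 (0.15 log units; within the scatter) seen in the measured pair. Compound 4 is therefore estimated at 11000 nM, with a range from 5500 nM to 22000 nM.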

Compound 4, half-maximal inhibitory concentration: 4300 nM
Estimate against measurement, compound 4: 2.6-fold (0.41 log units) above, outside the stated range (below it).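

Hydrogen in place of methyl on the aromatic carbon gives a 3.6-fold lower number from compound 3 to compound 4 (0.56 log units; beyond the scatter) in this assay, and this step lies beyond the scatter, whereas the earlier step on the core of compound 2 does not. Even so, the two steps cannot be told apart, so the change carries between these two cores without a measurable difference in its size: the same change on two cores in this assay, a 1.4-fold lower number (0.15 log units; within the scatter) from compound 2 to compound 1 and a 3.6-fold lower number (0.56 log units; beyond the scatter) from compound 3 to compound 4, 2.5-fold (0.41 log units) apart, within the scatter of two such steps.
For the compounds shown here, this rests on only two pairs in one assay, so it fixes no size for the step and shows nothing about other cores.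

Still open, as far as these compounds go, is whether an amine or a methoxy group opposite the ring nitrogen would shift the number in either direction. A larger group, such as a longer alkyl chain, at that place also remains untested among the compounds shown here.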